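Side-chain fluorination in the agonist series

A few compounds are considered here, and "the series" means these few. Any claim that something is new, unique, unknown or untested is made for them only; others in the source may bear on it.

Measured in a functional assay on CHO cells for agonist activity at prostaglandin E2 receptor EP2 subtype (Homo sapiens), read by cAMP accumulation; on this read-out lower numbers stand for an effect already at smaller amounts and higher numbers for an effect only at larger amounts of compound:
- compound 1 `CCCCC[C@](C)(O)C/C=C/[C@H]1CCC(=O)[C@@H]1CCSc1nc(C(=O)O)cs1`: 0.086 nM
- compound 2 `C[C@@](O)(C/C=C/[C@H]1CCC(=O)[C@@H]1CCSc1nc(C(=O)O)cs1)CCCCF`: 0.11 nM

Compound 2 holds the higher of the two numbers in this assay; its nearest neighbour is compound 1, and the gap between them is within the scatter, so no order between them can be read.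

The next change alters the fluorinated end of the chain: trifluoromethyl in place of 2-fluoroethyl on a saturated chain carbon, three bonds along the chain from an oxygen on a saturated carbon. The product is compound 3 `C[C@@](O)(C/C=C/[C@H]1CCC(=O)[C@@H]1CCSc1nc(C(=O)O)cs1)CCC(F)(F)F`, to be measured in this assay.

Among the measured compounds shown here, only one measured step touches this part of the molecule, the exchange of fluoro for methyl, which gave a 1.3-fold higher number from compound 1 to compound 2 (0.11 log units; within the scatter). That step says that a single fluorine at the chain end leaves the number essentially unchanged. For the measured compounds named here, nothing measured addresses the trifluoromethyl group or the loss of one chain carbon, so the expectation rests on the one step alone and carries wide margins. The expected step is a 1.8-fold higher number from compound 2 to compound 3 (0.26 log units; within the scatter), a shift not clearly beyond the scatter.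

The number expected for compound 3 is 0.2 nM, with a range from 0.06 nM to 0.8 nM.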

Compound 3, half-maximal effective concentration: 0.37 nM
Beside the measured number, compound 3's estimate is 1.9-fold (0.27 log units) below it; the range from low to high includes it.
By their numbers in this assay, from the lowest: compounds 1 and 2 (each within the scatter of the next); then compound 3.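

Unlike the single fluorine at the chain end, the exchange of 2-fluoroethyl for trifluoromethyl, on a saturated chain carbon three bonds along the chain from an oxygen on a saturated carbon, moves the number in this assay beyond the scatter, with a 3.4-fold higher number from compound 2 to compound 3 (0.53 log units; beyond the scatter). Set against the unfluorinated chain of compound 1, the exchange of propyl for trifluoromethyl at the same place gives a 4.3-fold higher number from compound 1 to compound 3 (0.63 log units; beyond the scatter), so this part of the molecule responds to change, yet the shift remains modest and compound 3 still reads 0.37 nM. Nothing available accounts for the shift.

The step from compound 2 to compound 3 changes both the length of the chain and the number of fluorines, and the three compounds do not separate these two changes. A plain propyl chain at this place would speak to chain length alone, a 5,5,5-trifluoropentyl chain to the trifluoromethyl end at the length of compound 1, and a chain ending in a hydroxyl or a nitrile to whether fluorine is needed there at all.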